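From naphthalen-1-yl to 2-methoxyphenyl in compound 4

The source may hold more compounds than are shown below. What is called first, only, known or untested is meant among the compounds shown, and "the series" means these compounds.

Values measured in a functional assay on HCT-116 cells (Homo sapiens) for inhibition, read by sulforhodamine B assay, with a stated time of 48 h, tested at 50 uM (on this read-out higher numbers stand for more inhibition of growth at the one concentration tested and lower numbers for less inhibition of growth), for three compounds
compound 1 `COc1ccc(/C=C/C(=O)/C=C/c2ccc(OCc3cn(CCCCCOc4cc(=O)oc5ccccc45)nn3)c(OC)c2)cc1OC` gives 45%
compound 2 `COc1cc(/C=C/C(=O)/C=C/c2ccccc2)ccc1OCc1cn(CCCCOc2cc(=O)oc3ccccc23)nn1` gives 34%
compound 3 `COc1cc(/C=C/C(=O)/C=C/c2cccc3ccccc23)ccc1OCc1cn(CCCCOc2cc(=O)oc3ccccc23)nn1` gives 56%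

Compound 3 at 56% is the highest of the three, while compound 1 at 45% and compound 2 at 34% both lie lower by more than the scatter. Compound 4 `COc1ccccc1/C=C/C(=O)/C=C/c1ccc(OCc2cn(CCCCOc3cc(=O)oc4ccccc34)nn2)c(OC)c1` has not yet been measured. Its change from compound 3 is 2-methoxyphenyl in place of naphthalen-1-yl on a double-bonded chain carbon bound to a double-bonded chain carbon with 2-methoxyphenyl in place of naphthalen-1-yl on a double-bonded chain carbon bound to a double-bonded chain carbon. Among the compounds with values here, one measured step bears on this place, namely a number 22 percentage points higher from compound 2 to compound 3 (beyond the scatter) for naphthalen-1-yl in place of phenyl. Compound 4 returns to one aromatic ring, as compound 2 has, so a downward step is expected in this assay that is somewhat smaller than the measured one. Within the data shown here, no measured step shows what the methoxy alone does here, and compound 1 differs from compound 2 in more than one place. The expectation is a number 14 percentage points lower from compound 3 to compound 4 (beyond the scatter) as an estimated fall. Compound 4 is estimated at 42% with 28% as the expected lower end and 56% as the upper end.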

Compound 4, percent growth inhibition at one concentration: 43%
For compound 4 the middle estimate is 1 percentage points below the measured one; low and high end bracket the measured number.
By their numbers in this assay, from the lowest: compounds 2, 4 and 1 (each within the scatter of the next, the first and the last beyond it); then compound 3.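

In this assay, 2-methoxyphenyl in place of naphthalen-1-yl on a double-bonded chain carbon bound to a double-bonded chain carbon gives a number 13 percentage points lower from compound 3 to compound 4 (beyond the scatter), so among the groups shown here, naphthalen-1-yl alone stands apart from the others at this place. Methoxy in place of hydrogen on an aromatic carbon gives a number 9 percentage points higher from compound 2 to compound 4 (within the scatter), so this read-out does not separate the methoxy compound from the unsubstituted phenyl compound, which the earlier compounds could not show. No measured evidence is available to explain either step.

The compounds shown leave open whether naphthalen-2-yl at the same place would match naphthalen-1-yl, or whether the benefit is limited to that one group. They also leave open how a dimethylamino group or a carboxylic acid in place of the methoxy would read in this assay.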